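The source may hold more compounds than are shown below. What is called first, only, known or untested is meant among the compounds shown, and "the series" means these compounds.

Among the compounds with values here, compound 2 `FC(F)(F)c1ccc(CSc2nc(Nc3cccc(Br)c3)c3ccccc3n2)cc1` gives in a functional assay on MCF7 cells (Homo sapiens) for cytotoxicity, read by MTT assay, with a stated time of 72 h (on this read-out higher numbers stand for weaker inhibition and lower numbers for stronger inhibition), the value 25600 nM, the only number in the set. Compound 1 `FC(F)(F)c1ccc(CSc2nc(Nc3ccccc3Cl)c3ccccc3n2)cc1` gives in this assay only a limit, > 50000 nM. Within the data shown here, the single step between them, an at least 1.9-fold lower number from compound 1 to compound 2 (0.29 log units; that floor lies within the scatter), rests on that limit (the limit of > 50000 nM in this assay, at which 1 of the 2 values shown sits). Compound 3 `Cc1ccc(Nc2nc(SCc3ccc(C(F)(F)F)cc3)nc3ccccc23)cc1` differs from compound 2 by 4-methylphenyl in place of 3-bromophenyl on a nitrogen on an aromatic ring. The measured step exchanges the aryl group on the same nitrogen, but its floor lies within the scatter, so it gives no direction. The expected step is therefore a 1.2-fold higher number from compound 2 to compound 3 (0.07 log units; within the scatter) in this assay, none beyond the scatter. Compound 3 is estimated at 30000 nM, range 8000 nM to 100000 nM, with a real chance that this assay again returns only a limit.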

Compound 3, half-maximal inhibitory concentration: > 50000 nM
Compound 3 was reported as a limit; the forecaster's own chance of this, stated with the estimate: 35%; at least 1.6-fold (0.22 log units) between middle value and limit.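

At this position, 4-methylphenyl in place of 3-bromophenyl gives an at least 1.9-fold higher number from compound 2 to compound 3 (0.29 log units; that floor lies within the scatter), so this exchange, like the earlier one, sets no direction. The new point is that an aryl group without halogen also ends at a limit, so compound 2 alone carries a number, and the limit is not confined to the halogen-bearing 2-chlorophenyl of compound 1: the limit of > 50000 nM in this assay, at which 2 of the 3 values shown sit. The step from compound 1 to compound 3 cannot be read.

Open, on these data alone, is whether an amine or a carboxylic acid on this aryl ring would give a number clear of that limit. Also open, as far as these compounds go, is whether a longer chain in place of the aryl group would do so.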